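The source may hold more compounds than are shown below. What is called first, only, known or untested is meant among the compounds shown, and "the series" means these compounds.

Compound 1, `c1ccc(CN(CCCCN(C[C@H]2Cc3ccccc3CN2)[C@H]2CCCc3cccnc32)Cc2ccccn2)nc1`, gives > 30000 nM in a functional assay on cells for agonist activity at C-X-C chemokine receptor type 4 (Homo sapiens), read by fluorescence and calcium flux, with a stated time of 90 s (a higher number here means that more compound is needed for the effect, a lower number that less compound is needed), a limit of the assay.
Compound 2, `c1ccc2c(c1)CN[C@@H](CN(CCCCN(Cc1ccncc1)Cc1ccncc1)[C@H]1CCCc3cccnc31)C2`, gives > 30000 nM in this assay, again a limit.
Compound 3, `c1ccc(CN(CCCCN(C[C@H]2Cc3ccccc3CN2)[C@H]2CCCc3cccnc32)Cc2ccccc2)cc1`, gives > 30000 nM in this assay, also a limit.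

These three compounds share a core and differ in the groups on the nitrogen at the far end of the chain. None of them gives a number in this assay. Compound 3 sits at the limit of > 30000 nM in this assay, at which 3 of the 3 values shown sit. Among the compounds with values here, there is therefore no measured step between any two of them that can be read as a size or a direction: three limits side by side show only that each compound, under these conditions, needed more than the highest amount tested.

Compound 4, `c1ccc(CNCCCCN(C[C@H]2Cc3ccccc3CN2)[C@H]2CCCc3cccnc32)cc1`, is not yet measured. Compared with compound 3 the change is hydrogen in place of benzyl on an amine nitrogen, leaving a secondary amine where a tertiary one stood. Nothing among the shown compounds tells how such a change acts, since no pair of them yields a measured step. The expectation is therefore a weak one: compound 4 is most likely to come out again at the limit, and the step from compound 3 to compound 4 is expected to be a step that the limit leaves unreadable from compound 3 to compound 4, that is, none beyond the scatter that could be told apart. As a value, compound 4 is expected at about 40000 nM, within a range from 10000 nM to 150000 nM.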

Compound 4, half-maximal effective concentration: > 30000 nM
Compound 4: no number, only a limit; the forecaster's own chance of this, stated with the estimate: 75%; the middle value lies beyond the limit too.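

Compound 3 and compound 4 both stand at a limit of the assay rather than at a number, so no step between them can be read, in size or in direction: the limit of > 30000 nM in this assay, at which 4 of the 4 values shown sit.

The compounds shown leave open which group on the amine nitrogen, if any, would give a measured number in this assay.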